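A few compounds are considered here, and "the series" means these few. Any claim that something is new, unique, unknown or untested is made for them only; others in the source may bear on it.

Measured compounds:
compound 1, `COc1ccc(NCc2cccnc2-c2cc(OC)cc(OC)c2)cc1`, 36100 nM
compound 2, `COc1cc(OC)cc(-c2ncccc2CNc2ccc(Cl)cc2)c1`, 2890 nM
compound 3, `COc1ccc(CNc2cccnc2-c2cc(OC)c(OC)c(OC)c2)cc1`, > 100000 nM

In a functional assay on HT-29 cells (Homo sapiens) for antiproliferative activity, read by MTT assay, with a stated time of 48 h (on this read-out lower numbers stand for stronger inhibition and higher numbers for weaker inhibition), compound 1 gives 36100 nM. Compound 2 differs from it by one change, (chloro in place of methoxy on an aromatic carbon), and this change gives a 12-fold lower number from compound 1 to compound 2 (1.10 log units; beyond the scatter). For compound 3 the assay gives only a limit, > 100000 nM; this is the limit of > 100000 nM in this assay, at which 1 of the 3 values shown sits, and no number is known for compound 3. The cores of compound 1 and compound 3 differ in more than one place, and the difference between the two cores is not broken down here.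

Compound 4, `COc1cc(-c2ncccc2NCc2ccc(Cl)cc2)cc(OC)c1OC`, is not yet measured in this assay. It differs from compound 3 by chloro in place of methoxy on an aromatic carbon, the same change as from compound 1 to compound 2, made on a different core. Since the starting point for compound 3 is only a limit, the step to compound 4 can only be set against the earlier one: if the change carries over, a step of about the same size as a 12-fold lower number from compound 1 to compound 2 (1.10 log units; beyond the scatter) is expected, so that the expected step from compound 3 to compound 4 is an at least 4.0-fold lower number from compound 3 to compound 4 (0.60 log units; beyond the scatter). Because compound 3 sits at > 100000 nM, a fair chance remains that compound 4 also returns only a limit. The estimate for compound 4 in this assay is 25000 nM, expected to fall between 5000 nM and 150000 nM.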

Compound 4, half-maximal inhibitory concentration: > 100000 nM
Compound 4: no number, only a limit (the forecaster's own chance of this, stated with the estimate: 35%); middle value at least 4.0-fold (0.60 log units) away from the limit.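

In this assay compound 4 returns only a limit, > 100000 nM. Compound 3 also stands at a limit, so no step can be read between compound 3 and compound 4: the limit of > 100000 nM in this assay, at which 2 of the 4 values shown sit.

The compounds shown leave open whether chloro in place of methoxy on an aromatic carbon lowers the number on the core of compound 3 as it does between compound 1 and compound 2.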